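Ethyl to Methyl: Compound 3 Leads to Compound 4

The source may hold more compounds than are shown below. What is called first, only, known or untested is meant among the compounds shown, and "the series" means these compounds.

Of the compounds shown here, three have so far been measured in a functional assay on the whole organism (strain Sprague-Dawley) for inhibition, with Rattus norvegicus as the target; on this read-out higher numbers stand for an effect only at larger amounts of compound and lower numbers for an effect already at smaller amounts. Compound 1 `CCc1cccc2cc(C(=O)O)cnc12` gives 75 mg/kg in this assay. For compound 2 `O=c1c(-c2nn[nH]n2)c[nH]c2c(Cl)c(Cl)ccc12` the read-out is only a limit of the assay, > 10 mg/kg, and not a number. For compound 3 `CCc1cccc2c(=O)c(-c3nn[nH]n3)c[nH]c12` the read-out is likewise only a limit of the assay, > 25 mg/kg, and not a number. Compound 3 therefore stands at the limit of > 25 mg/kg in this assay, at which 1 of the 3 values shown sits, while one further value among the three sits at the limit of > 10 mg/kg in this assay, at which 1 of the 3 values shown sits; compound 1 alone gives a number. Among the measured compounds shown here, no two of the measured compounds differ in a single place, so no measured step is available to guide the next one.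

Compound 4 `Cc1cccc2c(=O)c(-c3nn[nH]n3)c[nH]c12` differs from compound 3 by hydrogen in place of methyl on a saturated chain carbon bound to an aromatic carbon. For the measured compounds named here, because no measured step touches this part of the shared core, the size of this change is unknown; the step is expected to be small, of a size that stays within the usual scatter, with no clear direction, and the read-out may well end again at a limit of the assay. Compound 4 is expected to give about 40 mg/kg in this assay, within a range from 15 mg/kg to 120 mg/kg. The expected step is a step that the limit leaves unreadable from compound 3 to compound 4.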

Compound 4, minimum effective dose: > 10 mg/kg
Compound 4 ended at the assay's limit (the forecaster's own chance of this, stated with the estimate: 60%); the middle value is on the limit's open side.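

In this assay compound 3 gives only a limit of the assay, not a number: the limit of > 25 mg/kg in this assay, at which 1 of the 4 values shown sits. Compound 4 likewise ends at a limit: the limit of > 10 mg/kg in this assay, at which 2 of the 4 values shown sit. Among the compounds shown here, no step between compound 3 and compound 4 can be read from these two limits. The compounds shown leave open whether going from ethyl to methyl changes the minimum effective dose at all.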